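A few compounds are considered here, and "the series" means these few. Any claim that something is new, unique, unknown or untested is made for them only; others in the source may bear on it.

Measured so far in a functional assay on HeLa cells (Homo sapiens) for inhibition, read by MTT assay, with a stated time of 72 h; on this read-out lower numbers stand for stronger inhibition and higher numbers for weaker inhibition:
Compound 1 `COc1cc(NC(C)CCCNC(=O)NNC(=O)Nc2cccc(F)c2)c2ncccc2c1` gives only a limit of the test, > 250000 nM.
Compound 2 `COc1cc(NC(C)CCCNC(=O)NNC(=O)Nc2ccc(Br)cc2)c2ncccc2c1` gives 101000 nM.

For the measured compounds named here, compound 2 therefore supplies the single real number among the two results; the other result is a limit (the limit of > 250000 nM in this assay, at which 1 of the 2 values shown sits), so compound 2 is the only firm point of reference. Going by the values given here, the one measured step, an at least 2.4-fold lower number from compound 1 to compound 2 (0.39 log units; beyond the scatter), shows that swapping one halogenated phenyl group for another moved the result by a modest but genuine amount.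

Compound 3 `COc1cc(NC(C)CCCNC(=O)Nc2ccc(Cl)cc2)c2ncccc2c1` is built from compound 2 by a different kind of change: 4-chlorophenyl in place of ((4-bromophenyl)carbamoyl)amino on an amide-type nitrogen. The measured step kept the carbamoylamino unit and changed only the halogen on the phenyl ring; the change to compound 3 removes that unit entirely, leaving a shorter link to a chlorinated phenyl ring. Among the compounds with values here, no measured pair mirrors this, so the earlier step gives no direct guide to its size or direction. Without such a guide, the expectation is for a result close to compound 2, with no step beyond the scatter. Compound 3 is therefore estimated at 100000 nM, within a range of 30000 nM to 300000 nM. This estimate implies a step of a 1.0-fold lower number from compound 2 to compound 3 (0.00 log units; within the scatter).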

Compound 3, half-maximal inhibitory concentration: 18000 nM
For compound 3 the middle estimate is 5.6-fold (0.74 log units) above the measured one; the measured number lies below the stated range.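

In this assay, the step of a 5.6-fold lower number from compound 2 to compound 3 (0.75 log units; beyond the scatter) shows that the result at this place on the amide-type nitrogen depends on more than the halogenated phenyl ring, which was the only part that differed between compound 1 and compound 2. Replacing the whole ((4-bromophenyl)carbamoyl)amino group with 4-chlorophenyl leaves a shorter link to the ring and gives the firmest number of the series, a step clearly beyond the scatter. The step of an at least 13-fold lower number from compound 1 to compound 3 (1.14 log units; beyond the scatter) is large, but its starting point is a limit rather than a number: the limit of > 250000 nM in this assay, at which 1 of the 3 values shown sits.

The change to compound 3 removes the carbamoylamino unit and replaces bromine with chlorine at the same time, so these compounds cannot show how much of the step belongs to each; a 4-bromophenyl group on the shorter link would separate the two. From the compounds shown here alone, it also stays open whether a plain phenyl ring without a halogen, an amine or a longer chain at this place would give a lower or a higher number than compound 3.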